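The source may hold more compounds than are shown below. What is called first, only, known or untested is meant among the compounds shown, and "the series" means these compounds.

Of the compounds shown here, three have been measured in an assay on isolated protein for binding affinity to leukotriene B4 receptor 1 (Homo sapiens), tested at 1 uM; a lower number here means less inhibition, a higher number more inhibition at the concentration tested (going by the name of the read-out). Compound 1 `C=CCc1cc(C(C)=O)c(O)cc1OCCCCCCCCC#N` gives 50%. Compound 2 `CCc1cc(C(C)=O)c(O)cc1OCCCCCCC(C)(C)C#N` gives 30%, the second highest of the three numbers; its nearest neighbour is compound 3 `CCCc1cc(C(C)=O)c(O)cc1OCCCCCC(=O)O` with 24%, a gap that lies within the usual scatter, while compound 1 sits above compound 2 by a gap that lies beyond it. Compound 4 `CCc1cc(C(C)=O)c(O)cc1OCCCCCCc1nnn[nH]1` has not yet been measured in this assay. It differs from compound 2 in one place: 1H-tetrazol-5-yl in place of 1-cyano-1-methylethyl on a saturated chain carbon, six bonds along the chain from an oxygen on an aromatic ring. Among the compounds with values here, no pair of measured compounds differs in a single place, so no measured step guides this change. The change is expected to move the number only a little, a number 5 percentage points higher from compound 2 to compound 4 (within the scatter), in no clear direction beyond the scatter. Compound 4 is estimated at 35%, within a range from 15% to 60%.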

Compound 4, a percentage reported as inhibition, at one concentration (the size of the read-out at that concentration, not a potency): 60%
The estimate for compound 4 lay 25 percentage points below the measured number, within the range that was stated.
By their numbers in this assay, from the lowest: compounds 3 and 2 (each within the scatter of the next); then compounds 1 and 4 (each within the scatter of the next).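

In this assay, within the data shown here, placing 1H-tetrazol-5-yl in place of 1-cyano-1-methylethyl on this saturated chain carbon gives a number 30 percentage points higher from compound 2 to compound 4 (beyond the scatter), the first measured step. The read-out therefore responds clearly to the group carried at this position, more than the estimate allowed for. No measurement shown gives a reason for this rise. A single step cannot separate the effect of gaining the 1H-tetrazol-5-yl ring from that of losing 1-cyano-1-methylethyl. As far as these compounds go, whether an amide or an amine at this position would give a similar number remains open.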